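This account rests on a few compounds, and the source may have more. Where it says the series, first, only, none or still open, it means among the compounds named here.

In an ADME assay on microsomes from liver (Rattus norvegicus, strain Sprague-Dawley) for metabolic stability, read by HPLC, using NADPH, with stated times of 5 min and 60 min, tested at 10 uM (a higher number here means that the compound lasts longer, a lower number that the compound disappears faster), compound 3 `COc1ccc(C(=O)NCc2ccc(NS(C)(=O)=O)cc2Cl)cc1` gives 4.5 h, the highest of the three numbers, ahead of compound 1 `CS(=O)(=O)Nc1ccc(CNC(=O)c2ccc(C34CC(C3)C4)cc2)c(Cl)c1` at 1.35 h and compound 2 `CN(C)c1ccc(C(=O)NCc2ccc(NS(C)(=O)=O)cc2Cl)cc1` at 0.883 h. Compound 4 `CS(=O)(=O)Nc1ccc(CNC(=O)c2ccc(N3CCCC3)cc2)c(Cl)c1` brings (pyrrolidin-1-yl in place of methoxy on an aromatic carbon), pyrrolidin-1-yl in place of methoxy on an aromatic carbon. Dimethylamino is the measured group closest to pyrrolidin-1-yl, so a 5.1-fold higher number from compound 2 to compound 3 (0.71 log units; beyond the scatter) bears most directly, and it lies beyond the scatter. Also beyond the scatter is a 3.3-fold higher number from compound 1 to compound 3 (0.52 log units; beyond the scatter), while a 1.5-fold lower number from compound 1 to compound 2 (0.18 log units; within the scatter) stays within it. For the measured compounds named here, no measured compound carries pyrrolidin-1-yl itself. A fall of similar size to the first of these steps, taken in reverse, is therefore expected in this assay. The expected change is a 4.5-fold lower number from compound 3 to compound 4 (0.65 log units; beyond the scatter). For compound 4 the estimate is 1 h, with an expected range of 0.4 h to 2.5 h.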

Compound 4, half-life: 1.28 h
Compound 4: the middle estimate sits 1.3-fold (0.11 log units) below what was measured, and the stated range covers the measured number.
By their numbers in this assay, from the lowest: compounds 2, 4 and 1 (each within the scatter of the next); then compound 3.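

In this assay, a second nitrogen-linked group on this aromatic carbon, para to a large group, also falls short of methoxy (a 3.5-fold lower number from compound 3 to compound 4 (0.55 log units; beyond the scatter)). Closing the amine into pyrrolidin-1-yl leaves no readable difference from dimethylamino (a 1.4-fold higher number from compound 2 to compound 4 (0.16 log units; within the scatter)), and the group of compound 1 is likewise level with it (a 1.1-fold lower number from compound 1 to compound 4 (0.02 log units; within the scatter)), leaving compound 3 alone above three compounds that lie within the scatter. Nothing available explains the gap to methoxy.

Still open, as far as these compounds go, is whether an ether larger than methoxy, such as ethoxy, keeps the number of compound 3. Morpholin-4-yl would show whether a ring oxygen changes the pyrrolidin-1-yl result.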